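Phenylcarbamoyl variant of compound 3: expected antiproliferative potency

The compounds below may be only part of what the source reports. "The series", "measured", "known", "first", "only" and "open" are said of these compounds alone.

Compound 1 `CNC(=O)c1cc(Oc2ccc(/C=C/c3ccccn3)cc2)ccn1` gives 21600 nM in a functional assay on HepG2 cells (Homo sapiens) for antiproliferative activity, read by CCK-8 assay, with a stated time of 48 h; on this read-out higher numbers stand for weaker inhibition and lower numbers for stronger inhibition. Compound 2 `O=C(Nc1ccccc1)c1cc(Oc2ccc(/C=C/c3ccccn3)cc2)ccn1` gives 30200 nM in this assay; the step between them is a 1.4-fold higher number from compound 1 to compound 2 (0.15 log units; within the scatter). Compound 3 `CNC(=O)c1cc(Oc2ccc(/C=C/c3ccncc3)cc2)ccn1` gives 18200 nM in this assay; the step here is a 1.2-fold lower number from compound 1 to compound 3 (0.07 log units; within the scatter). Within the data shown here, on the numbers so far compound 3 has the lowest of the three values, but its separation from compound 1 and from compound 2 lies within the scatter, so no ordering of the three can be drawn from them.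

Compound 4 `O=C(Nc1ccccc1)c1cc(Oc2ccc(/C=C/c3ccncc3)cc2)ccn1` differs from compound 3 by phenyl in place of methyl on an amide-type nitrogen. Among the measured compounds shown here, the one measured step that bears on this exchange is a 1.4-fold higher number from compound 1 to compound 2 (0.15 log units; within the scatter), the same replacement made on the pyridin-2-yl analogue, and it stayed within the scatter. The pyridin-4-yl and pyridin-2-yl variants themselves are separated only by a 1.2-fold lower number from compound 1 to compound 3 (0.07 log units; within the scatter), so nothing in the data suggests the phenyl exchange should behave differently on compound 3. The expected step is therefore a 1.4-fold higher number from compound 3 to compound 4 (0.14 log units; within the scatter), a small shift toward a higher number in this assay at most, not beyond the scatter. Compound 4 is estimated at 25000 nM in this assay, with a range from 12000 nM to 52000 nM.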

Compound 4, half-maximal inhibitory concentration: > 100000 nM
Compound 4 gave a limit, no number (the forecaster's own chance of this, stated with the estimate: 15%); middle value at least 4.0-fold (0.60 log units) away from the limit.
By their numbers in this assay, from the lowest: compounds 3, 1 and 2 (each within the scatter of the next). At a limit, above all of these: compound 4.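

In this assay compound 4 gives > 100000 nM, which is a limit of the assay and not a number. With pyridin-4-yl on the chain, phenyl in place of methyl on the amide-type nitrogen gives an at least 5.4-fold higher number from compound 3 to compound 4 (0.73 log units; beyond the scatter), so what this nitrogen tolerates depends on the pyridine variant elsewhere in the molecule, as the same exchange on the pyridin-2-yl compounds stays within the scatter: the same change on two cores in this assay, a 1.4-fold higher number (0.15 log units; within the scatter) from compound 1 to compound 2 and an at least 5.4-fold higher number (0.73 log units; beyond the scatter) from compound 3 to compound 4, at least 3.9-fold (0.59 log units) apart, beyond the scatter of two such steps. Read the other way, pyridin-4-yl in place of pyridin-2-yl makes no difference beyond the scatter with methyl on the amide-type nitrogen but gives an at least 3.3-fold higher number from compound 2 to compound 4 (0.51 log units; beyond the scatter) with phenyl there, so the two changes cannot be treated as independent in this series: the same change on two cores in this assay, a 1.2-fold lower number (0.07 log units; within the scatter) from compound 1 to compound 3 and an at least 3.3-fold higher number (0.51 log units; beyond the scatter) from compound 2 to compound 4, at least 3.9-fold (0.59 log units) apart, beyond the scatter of two such steps.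

The compounds shown carry only methyl or phenyl on this nitrogen, and an ethyl, cyclopropyl or benzyl group on the pyridin-4-yl core would show where in that range the values start to climb. As far as these compounds go, how far the true value of compound 4 lies past its limit remains open, and with it the full size of both steps.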